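The source may report more compounds than this note shows. Statements on the series, on what has been measured and on what is new or still open speak of the compounds shown alone.

Compound 1, `Cc1nc(-c2ccc(F)cc2)sc1COc1ccc(S(=O)(=O)CC(=O)O)cc1` — in an assay on CHO cells for agonist activity at Free fatty acid receptor 1 (Homo sapiens), read by FLIPR (a lower number here means that less compound is needed, a higher number that more compound is needed for the effect), compound 1 gives 253 nM.
Compound 2, `Cc1nc(-c2ccccc2)sc1COc1ccc(CCC(=O)O)cc1` — in this assay compound 2 gives 590 nM.

Of the two measured compounds, compound 2 shows the higher number; its nearest neighbour is compound 1, which lies beyond the usual scatter below it. The two share the same core, but they differ in more than one place, so the gap between them cannot be tied to a single change.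

Compound 3, `Cc1nc(-c2ccc(F)cc2)sc1COc1ccc(CCC(=O)O)cc1`, has not yet been measured. It differs from compound 2 in one place: fluoro in place of hydrogen on an aromatic carbon. Seen one bond further out, a phenyl becomes a 4-fluorophenyl, and compound 3 thereby carries the same aryl group as compound 1 while keeping the acid-bearing chain of compound 2. Going by the values given here, no single-change step between measured compounds exists here, so the size of this change is open. For compound 3 the expected step is a 1.3-fold lower number from compound 2 to compound 3 (0.12 log units; within the scatter), small and likely within the scatter, if anything towards a lower number. On that basis compound 3 is estimated at 450 nM, with a range from 200 nM to 1000 nM.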

Compound 3, half-maximal effective concentration: 251 nM
Estimate against measurement, compound 3: 1.8-fold (0.25 log units) above; low and high end bracket the measured number.
By their numbers in this assay, from the lowest: compounds 3 and 1 (each within the scatter of the next); then compound 2.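

In this assay, going by these compounds alone, the change from phenyl to 4-fluorophenyl, fluoro in place of hydrogen on an aromatic carbon para to a large group, gives a 2.4-fold lower number from compound 2 to compound 3 (0.37 log units; beyond the scatter) and so provides the first single-change reading at this position, a modest step. With the 4-fluorophenyl held constant, 2-carboxyethyl in place of (carboxymethyl)sulfonyl gives a 1.0-fold lower number from compound 1 to compound 3 (0.00 log units; within the scatter) and leaves the fluoro step as the only one of the two that lies beyond the scatter, so these two acid-bearing chains cannot be told apart in this pair. Nothing at hand accounts for the size of either step.

From the compounds shown here alone, it remains open whether chloro or methoxy in the same place would give a step of similar size, and whether the fluoro step would carry over to compounds bearing the (carboxymethyl)sulfonyl chain. Also open, going by these compounds, is how a longer chain ending in the carboxylic acid, or a tetrazole in place of that acid, would read against these two chains in this assay on the 4-fluorophenyl series.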